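Changing the amide side chain of compound 2

The source may hold more compounds than are shown below. What is called first, only, known or untested is meant among the compounds shown, and "the series" means these compounds.

Measured so far in an ADME assay on microsomes from liver (Mus musculus, strain CD-1) for metabolic stability, read by LC-MS, tested at 2 uM (a higher number here means that the compound lasts longer, a lower number that the compound disappears faster), are two compounds.

- Compound 1 `Cn1ccc2ccc(-c3cc(Nc4cnccc4C(=O)NCc4cncnc4)cc4nccnc34)cc21` gives 0.4 h
- Compound 2 `CC(=O)N1CCOC(CNC(=O)c2ccncc2Nc2cc(-c3ccc4ccn(C)c4c3)c3nccnc3c2)C1` gives 0.217 h

Compound 2 stands within the scatter of compound 1 (a 1.8-fold lower number from compound 1 to compound 2 (0.27 log units; within the scatter)). Compound 3 `CC(=O)N1CCC(NC(=O)c2ccncc2Nc2cc(-c3ccc4ccn(C)c4c3)c3nccnc3c2)C1` differs from compound 2 at one place, on an amide-type nitrogen (1-acetylpyrrolidin-3-yl in place of (4-acetylmorpholin-2-yl)methyl on an amide-type nitrogen). That single measured step bears on this change only loosely, since it swapped a different group in the same side chain. It stayed within the scatter, so no step beyond the scatter and no clear direction is expected in this assay. The estimated change is small (a 1.0-fold higher number from compound 2 to compound 3 (0.01 log units; within the scatter)). For compound 3 the expected half-life is 0.22 h, with an estimated range from 0.1 h to 0.45 h.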

Compound 3, half-life: 0.667 h
Compound 3: middle estimate off by 3.0-fold (0.48 log units), on the low side, and the stated range ends below it.
By their numbers in this assay, from the lowest: compounds 2, 1 and 3 (each within the scatter of the next, the first and the last beyond it).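

In this assay, the amide side chain now gives a step beyond the scatter, as 1-acetylpyrrolidin-3-yl replaces (4-acetylmorpholin-2-yl)methyl (a 3.1-fold higher number from compound 2 to compound 3 (0.49 log units; beyond the scatter)). Set against (pyrimidin-5-yl)methyl, the same group stays within the scatter (a 1.7-fold higher number from compound 1 to compound 3 (0.22 log units; within the scatter)), so this position can shift the half-life, but the new group does not stand apart from the aromatic one. Nothing measured here explains the shift.

From the compounds shown here alone, this step alters the ring and the methyl link together, so their separate contributions remain open. Also open, going by these compounds, is how a side chain ending in a free amine or a carboxylic acid would behave.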